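Swapping an oxetane linker on the ring nitrogen

The compounds below may be only part of what the source reports. "The series", "measured", "known", "first", "only" and "open" are said of these compounds alone.

Measured compounds:
- compound 1, `CC(Sc1nc2nn(CC3COC3)cc2c(=O)n1-c1ccccc1)c1ccccc1`: 87%
- compound 2, `CC(Sc1nc2c(cnn2C)c(=O)n1-c1ccccc1)c1ccccn1`: 97%
- compound 3, `CC(Sc1nc2nn(C3COC3)cc2c(=O)n1-c1ccccc1)c1ccccc1`: "active" (no number reported); 98% (2 entries)

All three share one core and were tested in an assay on PEO1 cells for inhibition of Retinaldehyde dehydrogenase 3 (Homo sapiens), read by flow cytometry, with a stated time of 30 min, tested at 1 uM; a higher number here means more inhibition at the concentration tested (going by the name of the read-out), a lower number less inhibition. Compound 1 gives the lower of the two plain numbers, 87%, but its nearest neighbour, compound 2 with 97%, lies within the usual scatter, so no order between them can be claimed. Compound 3 was run more than once, and (the several entries of compound 3 in this assay, "active" (no number reported); 98% (2 entries)); it carries the oxetane ring directly on the aromatic nitrogen rather than through a one-carbon link.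

The unmeasured compound 4, `CC(Sc1nc2nn(C3(C)COC3)cc2c(=O)n1-c1ccccc1)c1ccccc1`, differs from compound 1 in one place: 3-methyloxetan-3-yl in place of (oxetan-3-yl)methyl on an aromatic nitrogen. Within the data shown here, no measured pair here differs in only that way, so the size of the step is not known from the data. Given that compound 3, which also carries the oxetane ring directly on the nitrogen, shows "active" (no number reported); 98% (2 entries), compound 4 is expected to sit high as well, with a step of a number 5 percentage points higher from compound 1 to compound 4 (within the scatter) that stays within the scatter. Compound 4 is estimated at 92%, likely between 78% and 99%.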

Compound 4, a percentage reported as inhibition, at one concentration (the size of the read-out at that concentration, not a potency) in the Retinaldehyde dehydrogenase 3 assay: 90%
Beside the measured number, compound 4's estimate is 2 percentage points above it, within the range that was stated.
By their numbers in the Retinaldehyde dehydrogenase 3 assay, from the lowest: compounds 1, 4 and 2 (each within the scatter of the next).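

In the Retinaldehyde dehydrogenase 3 assay, moving from (oxetan-3-yl)methyl to 3-methyloxetan-3-yl on an aromatic nitrogen gives a number 3 percentage points higher from compound 1 to compound 4 (within the scatter). The two groups have the same atoms joined differently, and at this position that rearrangement leaves no readable difference in inhibition at the concentration tested. In a physicochemical assay for solubility, using the shake flask method, in phosphate buffer, with a stated time of 24 h, at pH 7.4 (a higher number here means a more soluble compound, a lower number a less soluble compound), however, compound 1 gives 77000 nM and compound 4 gives 19000 nM, and the same change does register, as a loss of solubility: the measured solubility of compound 1, 77000 nM, and of compound 4, 19000 nM, a 4.1-fold lower number (0.61 log units; beyond the scatter)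

A single concentration gives no potency, so any difference in potency between compound 1 and compound 4 could remain hidden. The compounds shown also leave open whether a chain ending in an amine or a carboxylic acid on this nitrogen would keep the inhibition while giving a different solubility.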